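The compounds below may be only part of what the source reports. "The series", "measured", "known", "first", "only" and "open" are said of these compounds alone.

In a functional assay on HeLa cells (Homo sapiens) for antiproliferative activity, read by MTT assay, with a stated time of 48 h (on this read-out higher numbers stand for weaker inhibition and lower numbers for stronger inhibition), compound 1 `CN(C)CCn1c(N)c(-c2nc3ccccc3[nH]2)c2nc(C#N)c(C#N)nc21` gives 8880 nM and compound 2 `CN(C)CCCn1c(N)c(-c2nc3ccccc3[nH]2)c2nc(C#N)c(C#N)nc21` gives 25900 nM in this series. Compound 3 `N#Cc1nc2c(-c3nc4ccccc4[nH]3)c(N)n(CCCO)c2nc1C#N` stands at > 50000 nM, which is a limit of the assay and not a number. Compound 4 `CN(C)CCCCCn1c(N)c(-c2nc3ccccc3[nH]2)c2nc(C#N)c(C#N)nc21` follows from compound 3 by 2-(dimethylamino)ethyl in place of hydroxy on a saturated chain carbon, three bonds along the chain from an aromatic nitrogen, read as 3-hydroxypropyl to 5-(dimethylamino)pentyl. Replacing the hydroxy end undoes the kind of change seen in an at least 5.6-fold higher number from compound 1 to compound 3 (0.75 log units; beyond the scatter) and in an at least 1.9-fold higher number from compound 2 to compound 3 (0.28 log units; that floor lies within the scatter), so a lower number is expected. Extending the dimethylamino chain, seen once in a 2.9-fold higher number from compound 1 to compound 2 (0.46 log units; beyond the scatter), argues against a full recovery. A modest step in this assay is therefore expected, estimated as an at least 2.2-fold lower number from compound 3 to compound 4 (0.35 log units; beyond the scatter) overall. For compound 4 the estimate is 22000 nM, with an expected range from 9000 nM to 50000 nM as the working bracket.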

Compound 4, half-maximal inhibitory concentration: 10800 nM
For compound 4 the middle estimate is 2.0-fold (0.31 log units) above the measured one; measured number inside the range.
By their numbers in this assay, from the lowest: compounds 1 and 4 (each within the scatter of the next); then compound 2. At a limit, above all of these: compound 3.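

this assay reads an at least 4.6-fold lower number from compound 3 to compound 4 (0.66 log units; beyond the scatter) only as a floor, because compound 3 stands at a limit of the assay and not at a number: the limit of > 50000 nM in this assay, at which 1 of the 4 values shown sits.

Along the dimethylamino chains, the numbers show no steady loss with length: a 2.9-fold higher number from compound 1 to compound 2 (0.46 log units; beyond the scatter) is set against a 2.4-fold lower number from compound 2 to compound 4 (0.38 log units; beyond the scatter), leaving a 1.2-fold higher number from compound 1 to compound 4 (0.09 log units; within the scatter).

Open, as far as these compounds go, is how a 4-(dimethylamino)butyl chain or a chain longer than 5-(dimethylamino)pentyl would read here. Also open, from the compounds shown here alone, is whether a primary amine or a morpholine at the chain end would read like the dimethylamino end.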